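The source may report more compounds than this note shows. Statements on the series, on what has been measured and on what is new or still open speak of the compounds shown alone.

In an ADME assay on HOS cells (Homo sapiens) for cytotoxicity (on this read-out higher numbers stand for lower toxicity in this test and lower numbers for higher toxicity in this test), compound 3 (`CN(Cc1nc2cccc(CCCN)c2[nH]1)C1CCCc2cccnc21`) gives 10000 nM as its value. This lies within the usual scatter of compound 2 (`CN(C)CCCn1c(CN(C)C2CCCc3cccnc32)nc2ccccc21`), which gives 16800 nM here. The gap to compound 1 (`CN(Cc1nc2ccccc2n1CCCCCN)C1CCCc2cccnc21`) lies beyond the scatter, and compound 1 gives 4500 nM on the same read-out. Compound 4 (`CN1CCN(c2cccc3nc(CN(C)C4CCCc5cccnc54)[nH]c23)CC1`) carries 4-methylpiperazin-1-yl in place of 3-aminopropyl on an aromatic carbon. One measured step offers a loose guide: dimethylamino in place of 2-aminoethyl on a saturated chain carbon brought a 3.7-fold higher number from compound 1 to compound 2 (0.57 log units; beyond the scatter) at another place on the molecule. For the measured compounds named here, with only that modest step to go on, a small upward move is expected in this assay and it may stay within the scatter. The estimated step is a 1.3-fold higher number from compound 3 to compound 4 (0.11 log units; within the scatter) at the middle. For compound 4 the expected value is 13000 nM within an estimated range of 4500 nM to 35000 nM in this test.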

Compound 4, half-maximal cytotoxic concentration: 14000 nM
Compound 4: middle estimate off by 1.1-fold (0.03 log units), on the low side, and the stated range covers the measured number.
By their numbers in this assay, from the lowest: compound 1; then compounds 3, 4 and 2 (each within the scatter of the next).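

At this aromatic carbon, replacing the open 3-aminopropyl chain with the 4-methylpiperazin-1-yl ring brings a 1.4-fold higher number from compound 3 to compound 4 (0.15 log units; within the scatter) in this assay. The read-out therefore does not separate these two groups here, even though the entering group has a ring and no hydrogen-bond donors. Nothing measured here gives a reason for this result. On these data alone, it remains open whether a carboxylic acid or a simple methoxy group on this same carbon would also stay within the scatter of compound 3. A longer amine chain at this position is equally unresolved.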